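Turning One Stereocentre in a Fluorinated Alcohol

A few compounds are considered here, and "the series" means these few. Any claim that something is new, unique, unknown or untested is made for them only; others in the source may bear on it.

Measured compounds:
compound 1, `CCCC(O)CF`, gives 0.74 in a physicochemical assay for lipophilicity, read by NMR; on this read-out higher numbers stand for higher lipophilicity and lower numbers for lower lipophilicity.
compound 2, `C[C@H](O)C[C@@H](C)F`, gives 0.48 in this assay.
compound 3, `OCCCCF`, gives 0.09 in this assay.

Among these three, compound 2 sits close to compound 1, the two values lying within the scatter of each other, and clearly above compound 3, where the gap is beyond the scatter. No pair of these compounds differs in just one place, so no single structural step can be read off from them.

The unmeasured compound 4, `C[C@H](O)C[C@H](C)F`, is the diastereomer of compound 2. (the two compounds have the same atoms and bonds and differ only in configuration as drawn: 1 of 2 stereo elements differ; a stereocentre at a saturated chain carbon is drawn R in compound 2 and S in compound 4). This is a change in configuration only, with nothing entering or leaving the molecule.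

For compound 4 the account therefore expects a step in this assay of no size beyond the scatter, in no particular direction, since the atoms and bonds are unchanged and the three measured compounds give no stereochemical comparison of their own. The estimated step is a number 0.02 log units higher from compound 2 to compound 4 (within the scatter). On that basis compound 4 is estimated to give 0.5, within a range from 0.2 to 0.8.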

Compound 4, partition coefficient: 0.57
Compound 4: the middle estimate sits 0.07 log units below what was measured, and the stated range covers the measured number.
By their numbers in this assay, from the lowest: compound 3; then compounds 2, 4 and 1 (each within the scatter of the next).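

For the compounds shown here, compounds 1, 2 and 3 offered no pair differing in one place, so compound 4 supplies the first comparison in which a single structural feature can be isolated. In this assay, turning a stereocentre at a saturated chain carbon from R to S gives a number 0.09 log units higher from compound 2 to compound 4 (within the scatter), so this pair of diastereomers cannot be told apart on this read-out. The comparison concerns configuration alone, with no group entering or leaving, and the reason it can be read so directly is plain: the fact that compounds 2 and 4 differ only in the configuration as drawn

The compounds shown leave open whether the other stereo element of this pair would behave in the same way on inversion, since this single step speaks only for the one stereocentre that differs here. They also leave open whether configuration would remain as small a matter on a longer chain, or with an amine or a trifluoromethyl group in the molecule, as one step on one pair of diastereomers cannot be extended to such compounds.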